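The source may report more compounds than this note shows. Statements on the series, on what has been measured and on what is new or still open speak of the compounds shown alone.

Compound 1, `COc1cccc(/C=C2\CCC/C(=C\c3cc(Cl)cc(Cl)c3)C2=O)c1OC`, was tested in a functional assay on MCF7 cells (Homo sapiens) for cytotoxicity, read by MTT assay, with a stated time of 72 h (a lower number here means a stronger inhibitor, a higher number a weaker inhibitor), where compound 1 gives 4300 nM. Compound 2, `COc1cccc(/C=C2\CCC/C(=C\c3ccc(O)c(Cl)c3)C2=O)c1OC`, differs from it in one place: 3-chloro-4-hydroxyphenyl in place of 3,5-dichlorophenyl on a double-bonded chain carbon bound to a double-bonded ring carbon. In this assay compound 2 gives 16400 nM, so that this change made a 3.8-fold higher number from compound 1 to compound 2 (0.58 log units; beyond the scatter).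

Compound 3, `COc1ccc(/C=C2\CCC/C(=C\c3cc(Cl)cc(Cl)c3)C2=O)cc1OC`, is built from the same atoms as compound 1 joined differently; the difference between the two cores is not broken down here. In this assay compound 3 gives 3800 nM, and the two values of compound 3 and compound 1 lie within the usual scatter of one another, so nothing separates them.

Compound 4, `COc1ccc(/C=C2\CCC/C(=C\c3ccc(O)c(Cl)c3)C2=O)cc1OC`, has not yet been measured. It stands to compound 3 as compound 2 stands to compound 1, the same change at the same place: 3-chloro-4-hydroxyphenyl in place of 3,5-dichlorophenyl on a double-bonded chain carbon bound to a double-bonded ring carbon. Going by the values given here, because the single earlier instance of this change gave a 3.8-fold higher number from compound 1 to compound 2 (0.58 log units; beyond the scatter), a step of similar size is expected from compound 3 to compound 4, namely a 3.7-fold higher number from compound 3 to compound 4 (0.57 log units; beyond the scatter). On that basis compound 4 is estimated to give 14000 nM in this assay, most likely between 7000 nM and 30000 nM.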

Compound 4, half-maximal inhibitory concentration: 12300 nM
Compound 4: middle estimate off by 1.1-fold (0.06 log units), on the high side; the range from low to high includes it.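

On the core of compound 3, putting 3-chloro-4-hydroxyphenyl in place of 3,5-dichlorophenyl again gave a weaker result in this assay, with a 3.2-fold higher number from compound 3 to compound 4 (0.51 log units; beyond the scatter). Set beside the earlier case, the change carried over from one core to the other with no gap that can be told apart: the same change on two cores in this assay, a 3.8-fold higher number (0.58 log units; beyond the scatter) from compound 1 to compound 2 and a 3.2-fold higher number (0.51 log units; beyond the scatter) from compound 3 to compound 4, 1.2-fold (0.07 log units) apart, within the scatter of two such steps. This shows that in these two pairs the size of the step did not depend on which of the two cores bore it, but two pairs do not show that it would hold on any other core, nor do they explain why the number rises.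

The compounds shown leave open which part of the swap carries the step, the hydroxyl that enters or the chlorine that leaves. Also open, on these data alone, is how a methoxy, an amine or a carboxylic acid in place of that hydroxyl would behave on either core.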